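Trifluoromethyl for ethyl on the fused ring

A few compounds are considered here, and "the series" means these few. Any claim that something is new, unique, unknown or untested is made for them only; others in the source may bear on it.

Three compounds of the series have numbers in a functional assay on A-375 cells (Homo sapiens) for antiproliferative activity, read by MTT assay, with a stated time of 24 h, tested at 3.7 ug/mL; a higher number here means a stronger effect of the compound at the concentration tested, a lower number a weaker effect. Compound 1 `CCc1ccc2nc(C(=O)Nc3c(F)cc(-c4cccc(F)c4)cc3F)c(C)c(O)c2c1` gives 17.9%; compound 2 `CCOc1ccc2nc(C(=O)Nc3c(F)cc(-c4cccc(F)c4)cc3F)c(C)c(O)c2c1` gives 4.56%; compound 3 `CCc1ccc2nc(C(=O)Nc3c(F)cc(-c4cccc(F)c4)cc3F)c(C)c(C(=O)O)c2c1` gives 26.7%. Compound 3 stands highest of the three, with compound 1 nearest (a number 8.8 percentage points higher from compound 1 to compound 3 (within the scatter)) and compound 2 furthest, beyond the scatter. The change to compound 4 `Cc1c(C(=O)Nc2c(F)cc(-c3cccc(F)c3)cc2F)nc2ccc(C(F)(F)F)cc2c1C(=O)O` is trifluoromethyl in place of ethyl on an aromatic carbon. Going by the values given here, the only measured step at that aromatic carbon is a number 13.3 percentage points lower from compound 1 to compound 2 (beyond the scatter), where ethoxy replaced ethyl. Trifluoromethyl is not ethoxy, so that step is only a loose guide; a small drop or no change beyond the scatter is expected. Compound 4 is estimated at 22% (range 8% to 38%), meaning an expected step of a number 4.7 percentage points lower from compound 3 to compound 4 (within the scatter).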

Compound 4, a percentage reported as inhibition, at one concentration (the size of the read-out at that concentration, not a potency): 27.8%
Estimate against measurement, compound 4: 5.8 percentage points below; low and high end bracket the measured number.
By their numbers in this assay, from the lowest: compound 2; then compounds 1, 3 and 4 (each within the scatter of the next).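

In this assay, trifluoromethyl in place of ethyl on this aromatic carbon gives a number 1.1 percentage points higher from compound 3 to compound 4 (within the scatter) with the carboxy group present. Ethyl can therefore be replaced here without a shift beyond the scatter, unlike the earlier change to ethoxy in the hydroxy compounds, which gave a number 13.3 percentage points lower from compound 1 to compound 2 (beyond the scatter). Nothing available explains this difference.

From the compounds shown here alone, it remains open whether ethoxy would lower the number with the carboxy group present, or trifluoromethyl with the hydroxy group present. Going by these compounds, how an amine or a longer chain would read at this carbon is also open.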